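Para Difluoromethoxy in Place of Ethyl on the Sulfonamide Aryl

The source may report more compounds than this note shows. Statements on the series, on what has been measured and on what is new or still open speak of the compounds shown alone.

Two sulfonamides share one core. Compound 1 `Cc1cccc(NS(=O)(=O)c2ccc(N3CCNC3=O)cc2)c1` gives 110 nM in a functional assay on HT-29 cells (Homo sapiens) for antiproliferative activity, read by sulforhodamine B assay, with a stated time of 48 h (a higher number here means a weaker inhibitor, a lower number a stronger inhibitor), while compound 2 `CCc1ccc(NS(=O)(=O)c2ccc(N3CCNC3=O)cc2)cc1` gives 660 nM; the step of a 6.0-fold higher number from compound 1 to compound 2 (0.78 log units; beyond the scatter) corresponds to 4-ethylphenyl in place of 3-methylphenyl on the sulfonamide nitrogen. Compound 2 thus stands highest of the two numbers in this assay, its nearest neighbour being compound 1.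

Compound 3 `O=C1NCCN1c1ccc(S(=O)(=O)Nc2ccc(OC(F)F)cc2)cc1` is not yet measured. It differs from compound 2 as follows: difluoromethoxy in place of ethyl on an aromatic carbon. Among the measured compounds shown here, the only measured step, from compound 1 to compound 2, touched the same aryl ring but at a different place and with different groups, so it bears only loosely on this change. The measured data give no direct guide for difluoromethoxy in place of ethyl, and no step beyond the scatter is expected. Compound 3 is estimated at 600 nM in this assay, within 200 nM to 2000 nM, which means an expected step of a 1.1-fold lower number from compound 2 to compound 3 (0.04 log units; within the scatter).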

Compound 3, half-maximal inhibitory concentration: 650 nM
Beside the measured number, compound 3's estimate is 1.1-fold (0.03 log units) below it; the measured number falls inside the stated range.
By their numbers in this assay, from the lowest: compound 1; then compounds 3 and 2 (each within the scatter of the next).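

In this assay, difluoromethoxy in place of ethyl on the aromatic carbon para to a large group gives a 1.0-fold lower number from compound 2 to compound 3 (0.01 log units; within the scatter), so compound 2 and compound 3 cannot be told apart at this position. The earlier step, a 6.0-fold higher number from compound 1 to compound 2 (0.78 log units; beyond the scatter), altered the group and its place together, whereas this step alters the group alone and shows that these two groups can be exchanged here with no difference beyond the scatter. Nothing measured here accounts for this match.

From the compounds shown here alone, whether the match would extend to an amine, a carboxylic acid or a longer chain on this same aromatic carbon remains open. Also open, going by these compounds, is how difluoromethoxy would read at the ring position that carries the methyl group in compound 1.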